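Removing a tert-butyl group from a nucleoside analogue

This account rests on a few compounds, and the source may have more. Where it says the series, first, only, none or still open, it means among the compounds named here.

Measured compounds:
compound 1 `CC(=O)OC[C@H]1O[C@@H](n2cc(-c3cc(-c4ccc(C(C)(C)C)cc4)no3)c(=O)[nH]c2=O)C[C@@H]1OC(C)=O` gives 69.3%
compound 2 `CC(C)(C)c1ccc(Cn2cc(-c3cn([C@H]4C[C@H](O)[C@@H](CO)O4)c(=O)[nH]c3=O)nn2)cc1` gives 106%

Both numbers come from a functional assay on MDA-MB-231 cells (Homo sapiens) for cytotoxicity, read by sulforhodamine B assay, tested at 10 uM (a lower number here means less inhibition, a higher number more inhibition at the concentration tested (going by the name of the read-out)), a test of how strongly a compound at a single concentration holds back the growth of a breast cancer cell line. Compound 2 stands highest of the two; its nearest neighbour, compound 1, lies lower by a gap beyond the usual scatter, so the two are clearly told apart. Compound 1 and compound 2 differ in many places at once, so their two values show only that both act, compound 2 more fully.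

Compound 3, `O=c1[nH]c(=O)n([C@H]2C[C@H](O)[C@@H](CO)O2)cc1-c1cn(Cc2ccccc2)nn1`, keeps the whole of compound 2 except for one change: hydrogen in place of tert-butyl on an aromatic carbon The shared core remains untouched.

For the measured compounds named here, no measured pair in this set differs in only this one place, so there is no direct guide to the size of the step. Because compound 2 gives 106% and the change takes away the tert-butyl, the step in this assay is expected to go downward by a moderate amount, a number 26 percentage points lower from compound 2 to compound 3 (beyond the scatter). Compound 3 is expected to reach 80%, within a range from 50% to 105%.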

Compound 3, a percentage reported as inhibition, at one concentration (the size of the read-out at that concentration, not a potency): 103%
Compound 3: middle estimate off by 23 percentage points, on the low side, within the range that was stated.
By their numbers in this assay, from the lowest: compound 1; then compounds 3 and 2 (each within the scatter of the next).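

Replacing tert-butyl with hydrogen on the aromatic ring, which turns 4-(tert-butyl)phenyl into phenyl, gives in this assay a step of a number 3 percentage points lower from compound 2 to compound 3 (within the scatter), so the two compounds cannot be told apart in this test. At this place on the ring, then, the tert-butyl group and its four carbons are not needed to keep the reading at the single concentration tested, and the plain phenyl ring serves just as well. No measurement shown here explains why the change leaves the reading in place.

From the compounds shown here alone, whether the number stays level with any group at this position or simply with these two remains open, since an amine, a carboxylic acid or a longer chain in the same place could behave differently. Going by these compounds, this reading also reports the size of the effect at one concentration rather than a potency, so it remains open whether compound 2 and compound 3 would still match at lower concentrations.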